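A few compounds are considered here, and "the series" means these few. Any claim that something is new, unique, unknown or untested is made for them only; others in the source may bear on it.

Compound 1 `Cc1c(OCCCCOc2ccc(F)c(C(=O)O)c2)ccc(C(=O)CC(C)(C)C)c1O` is one of a small set examined in an assay on HEK293 cells for positive allosteric modulation of metabotropic glutamate receptor 3 (Rattus norvegicus), read by thallium flux, with a stated time of 2.5 min (on this read-out lower numbers stand for an effect already at smaller amounts and higher numbers for an effect only at larger amounts of compound), where compound 1 gives 258 nM. Compound 3 `Cc1c(OCCCCOc2ccc(C(=O)CC(C)(C)C)c(O)c2C)cccc1C(=O)O` carries a different group on an oxygen on a saturated carbon, and in this assay compound 3 gives 300 nM; the step of a 1.2-fold higher number from compound 1 to compound 3 (0.07 log units; within the scatter) leaves the two within the scatter of each other, so no order between them can be claimed. Compound 2 `CCC(=O)c1ccc(OCCCCOc2cccc(C(=O)O)c2C)c(C)c1O` also belongs to the set, but in this assay compound 2 gives "not determined" (no result reported). Compound 4 `Cc1c(OCCCCOc2ccc(F)c(C(=O)O)c2)ccc(C(=O)CC(C)C)c1O` differs from compound 1 on a saturated chain carbon bound to three saturated chain carbons: hydrogen in place of methyl on a saturated chain carbon bound to three saturated chain carbons. Among the compounds with values here, none of the measured steps touches this part of the molecule; the single measured step changes the group on the oxygen instead and stays within the scatter. With no direct guide, the account expects the step of a 1.6-fold higher number from compound 1 to compound 4 (0.19 log units; within the scatter) to be modest, tending if anything toward a somewhat higher number. The estimate for compound 4 in this assay is 400 nM, with a range from 150 nM to 1100 nM.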

Compound 4, half-maximal effective concentration: 920 nM
Compound 4: middle estimate off by 2.3-fold (0.36 log units), on the low side; the measured number falls inside the stated range.
By their numbers in this assay, from the lowest: compounds 1 and 3 (each within the scatter of the next); then compound 4.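

Going from tert-butyl to isopropyl gives a 3.6-fold higher number from compound 1 to compound 4 (0.55 log units; beyond the scatter) in this assay and is the first step in the set to lie beyond the scatter. Within the data shown here, the only other measured step, on the group on the oxygen, stayed within it, so the number responds here to the loss of a single methyl at the end of the neopentylcarbonyl chain, with no hydrogen-bond donor, hydrogen-bond acceptor or net charge entering or leaving. Nothing given here accounts for the size of this step.

From the compounds shown here alone, with only tert-butyl and isopropyl compared at this place, it remains open how a cyclopropyl group, a trifluoromethyl group or a longer chain would read there. Going by these compounds, it is also open whether the same change made on compound 3 would give a step of similar size.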